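The source may report more compounds than this note shows. Statements on the series, on what has been measured and on what is new or still open speak of the compounds shown alone.

Two compounds have been measured in an assay on H4IIE cells for inhibition of phosphoenolpyruvate carboxykinase, cytosolic [GTP] (Rattus norvegicus); a lower number here means that less compound is needed, a higher number that more compound is needed for the effect:

Compound 1, `O=c1c2[nH]c(Cc3ccc(NS(=O)(=O)c4cccnc4)cc3)nc2n(CC2CC2)c(=O)n1Cc1ccccc1F`, gives 5500 nM.
Compound 2, `CCCCn1c(=O)n(Cc2ccccc2F)c(=O)c2[nH]c(Cc3ccc(NC(C)=O)cc3)nc21`, gives 8600 nM.

Compound 1 and compound 2 share the same core, and their numbers in this assay lie within the usual scatter of each other, so nothing separates the two on the data at hand. Compound 3, `Cc1nn(C)cc1S(=O)(=O)Nc1ccc(Cc2nc3c([nH]2)c(=O)n(Cc2ccccc2F)c(=O)n3CC2CC2)cc1`, has not yet been measured in this assay. It differs from compound 1 in one place: 1,3-dimethyl-1H-pyrazol-4-yl in place of pyridin-3-yl on a sulfonyl sulfur. Going by the values given here, the only comparison available, between compound 1 and compound 2, changes a different part of the molecule, so no measured step shows what swapping one small aromatic ring for another on the sulfonyl sulfur does here. With nothing to point in either direction, the step from compound 1 to compound 3 is expected to stay within the scatter, as expressed by a 1.1-fold higher number from compound 1 to compound 3 (0.04 log units; within the scatter). Compound 3 is therefore estimated at 6000 nM in this assay, with a range from 2000 nM to 18000 nM.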

Compound 3, half-maximal effective concentration: 5570 nM
Beside the measured number, compound 3's estimate is 1.1-fold (0.03 log units) above it; the measured number falls inside the stated range.
By their numbers in this assay, from the lowest: compounds 1, 3 and 2 (each within the scatter of the next).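

In this assay, going by these compounds alone, putting 1,3-dimethyl-1H-pyrazol-4-yl in place of pyridin-3-yl on the sulfonyl sulfur gives a 1.0-fold higher number from compound 1 to compound 3 (0.01 log units; within the scatter), the first measured step at this position. The two groups differ in ring size and in their hetero atoms, yet their numbers cannot be told apart, so this position tolerates at least this one exchange of a six-membered aromatic ring for a five-membered one. No measurement at hand offers a reason for this result.

Going by these compounds, both groups tested here are small aromatic rings, so it remains open whether a plain methyl, a morpholine or a phenyl ring carrying a carboxylic acid on the same sulfonyl sulfur would give a number beyond the scatter of compound 1. Within the data shown here, it is also open whether any group at this position can bring the number down at all, since a single step within the scatter shows only that these two rings cannot be separated, not how far the position as a whole can respond.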